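The source may report more compounds than this note shows. Statements on the series, on what has been measured and on what is new or still open speak of the compounds shown alone.

In a functional assay on BV-2 cells (Mus musculus) for inhibition, read by Griess assay, with a stated time of 24 h (on this read-out lower numbers stand for stronger inhibition and higher numbers for weaker inhibition), compound 3 `CC(C)c1cc2c(c(CO)c(=O)c1)[C@H](O)C[C@@H]2C` gives 9000 nM, the lowest of the two exact numbers in the series, and compound 2 `Cc1c2c(cc(C(C)C)cc1=O)[C@@H](C)C[C@H]2O` gives 26000 nM. Compound 1 `Cc1c2c(cc(C(C)C)cc1=O)[C@@H](C)C[C@@H]2O` gives > 30000 nM, which is a limit of the assay. The step to compound 3 is a 2.9-fold lower number from compound 2 to compound 3 (0.46 log units; beyond the scatter), with hydroxy in place of hydrogen on a saturated chain carbon bound to an aromatic carbon.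

Compound 4 `CC(C)c1cc2c(c(CO)c(=O)c1)[C@@H](O)C[C@@H]2C` is the next case, with the two compounds have the same atoms and bonds and differ only in configuration as drawn: 1 of 2 stereo elements differ; a stereocentre at a saturated ring carbon is drawn R in compound 3 and S in compound 4. Within the data shown here, the only measured step of this kind is an at least 1.1-fold lower number from compound 1 to compound 2 (0.06 log units; that floor lies within the scatter), where a stereocentre at a saturated ring carbon is drawn S in compound 1 and R in compound 2. Compound 4 thus matches compound 1 in the drawn sense at that centre, and compound 3 matches compound 2. From the compounds shown here alone, that step gives only a floor, set by the limit of > 30000 nM in this assay, at which 1 of the 3 values shown sits, so its true size and direction remain open. A modest rise on inversion is the likeliest outcome, while the hydroxy step should keep the number from moving far. The expected change is a 1.7-fold higher number from compound 3 to compound 4 (0.22 log units; within the scatter). Compound 4 is estimated at 15000 nM, with an expected range of 6000 nM to 32000 nM.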

Compound 4, half-maximal inhibitory concentration: 20000 nM
Beside the measured number, compound 4's estimate is 1.3-fold (0.12 log units) below it; low and high end bracket the measured number.
By their numbers in this assay, from the lowest: compound 3; then compounds 4 and 2 (each within the scatter of the next). At a limit, above all of these: compound 1.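

Inversion at the saturated ring carbon now has a size that can be read in this assay: a 2.2-fold higher number from compound 3 to compound 4 (0.35 log units; beyond the scatter). This holds for the core that carries the added hydroxy on the chain carbon, whereas the earlier step of this kind, an at least 1.1-fold lower number from compound 1 to compound 2 (0.06 log units; that floor lies within the scatter), left both size and direction open, for want of an exact number for compound 1: the limit of > 30000 nM in this assay, at which 1 of the 4 values shown sits.

The hydroxy change also now appears with the other drawn configuration at the ring carbon: an at least 1.5-fold lower number from compound 1 to compound 4 (0.17 log units; that floor lies within the scatter). Compound 1 is a limit in that comparison, so the two hydroxy steps cannot be told apart: the same change on two cores in this assay, a 2.9-fold lower number (0.46 log units; beyond the scatter) from compound 2 to compound 3 and an at least 1.5-fold lower number (0.17 log units; that floor lies within the scatter) from compound 1 to compound 4; the limit leaves it open whether they differ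

The compounds shown leave open whether the configuration at the ring carbon still matters with an amine or a carboxylic acid in place of the hydroxy on the chain carbon. Also open, from the compounds shown here alone, are the true size of the inversion step on the core without that hydroxy and whether a methoxy group in place of the ring hydroxy would keep the numbers of compound 3 and compound 4 apart.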